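A few compounds are considered here, and "the series" means these few. Any claim that something is new, unique, unknown or untested is made for them only; others in the source may bear on it.

Three compounds have been put through a functional assay on CHO cells for antagonist activity at sphingosine 1-phosphate receptor 2 (Homo sapiens), read by calcium flux; a higher number here means a weaker inhibitor, a lower number a stronger inhibitor. Compound 1 `C[C@@H](C(=O)O)c1nn(Cc2cn3cc(OCC4CC4)c(Cl)cc3n2)c2ccccc2c1=O` gives 24 nM, the highest of the two numbers that were read outright. Compound 2 `C[C@H](C(=O)O)n1nc(Cn2cc3cc(OCC4CC4)c(Cl)cc3n2)c2ccccc2c1=O` gives 3.2 nM, a stronger inhibitor than compound 1 by a gap that lies beyond the usual scatter. Compound 3 `COc1cc(OC)c(NC(=O)Cc2cn(CC(=O)O)c3ccccc23)cc1Cl` is reported only as a limit of this assay, > 6640 nM, not as a number; the limit of > 6640 nM in this assay, at which 1 of the 3 values shown sits, marks the point at which that value sits.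

The piece follows the step from compound 1 to compound 4 `CC(C(=O)O)c1nn(Cc2cn3cc(OCC4CC4)c(Cl)cc3n2)c2ccccc2c1=O`, which has not yet been measured in this assay. The two compounds share every atom and bond; the difference is the two compounds have the same atoms and bonds; at least one stereo element is drawn with a configuration in one of them and without one in the other: 1 of 1 stereo elements differ; a stereocentre at a saturated chain carbon is drawn R in compound 1 and without a configuration in compound 4. Compound 1 is drawn as a single form at that centre, compound 4 without a drawn configuration, so compound 4 may stand for a mixture of both forms. Among the measured compounds shown here, nothing among the measured compounds shows how the two forms at this centre differ, since compound 2 carries a different arrangement of its core. Compound 4 is therefore expected to sit close to compound 1, with a step of a 1.5-fold higher number from compound 1 to compound 4 (0.16 log units; within the scatter) that need not exceed the usual scatter, though a somewhat weaker reading is expected as a real possibility if only one form carries the activity. The estimate for compound 4 in this assay is 35 nM, with a range from 12 nM to 110 nM.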

Compound 4, half-maximal inhibitory concentration: 6 nM
Compound 4: the middle estimate sits 5.8-fold (0.77 log units) above what was measured; measured number outside the range, below it.
By their numbers in this assay, from the lowest: compounds 2 and 4 (each within the scatter of the next); then compound 1. At a limit, above all of these: compound 3.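

Among the compounds shown here, the result gives the first measured step at the stereocentre on the saturated chain carbon: in this assay there is a 4.0-fold lower number from compound 1 to compound 4 (0.60 log units; beyond the scatter). Compound 1 is drawn R at this centre and compound 4 carries no drawn configuration, so if compound 4 is a mixture of both forms, the form absent from compound 1 must give a lower number than compound 1, and the R form would not be the stronger inhibitor of the two. Nothing else separates these two drawings, so the step can only be tied to how this one centre is defined: the fact that one of compounds 1 and 4 is drawn with a defined configuration and the other without, at the place where they differ

The compounds shown leave open what compound 4 actually contains, in what proportion, and what the opposite single form at this centre would give on its own. They also leave open how the number would move if an ethyl group took the place of the methyl at this centre, or if a tetrazole took the place of the carboxylic acid.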